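The source may hold more compounds than are shown below. What is called first, only, known or untested is meant among the compounds shown, and "the series" means these compounds.

Of the compounds shown here, three that share much of their structure have been measured in a functional assay on HCT-116 cells (Homo sapiens) for inhibition, read by sulforhodamine B assay, with a stated time of 48 h, tested at 50 uM; a lower number here means less inhibition of growth, a higher number more inhibition of growth at the concentration tested. There, compound 1 `COc1cccc(/C=C/C(=O)/C=C/c2ccc(OCc3cn(CCOc4cc(=O)oc5ccccc45)nn3)c(OC)c2)c1` gives 70%, compound 2 `COc1cc(/C=C/C(=O)/C=C/c2ccco2)ccc1OCc1cn(CCCCOc2cc(=O)oc3ccccc23)nn1` gives 47% and compound 3 `COc1cc(/C=C/C(=O)/C=C/c2cc(OC)c(OC)c(OC)c2)ccc1OCc1cn(CCCCCOc2cc(=O)oc3ccccc23)nn1` gives 53%. Compound 1 therefore stands highest of the three, beyond the scatter from both of the others, while compound 2 and compound 3 lie within the scatter of each other. For the measured compounds named here, neither of those two differs from compound 1 in only one place, so the data contain no measured step for a single structural change.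

The next compound is compound 4 `COc1ccc(/C=C/C(=O)/C=C/c2ccc(OCc3cn(CCOc4cc(=O)oc5ccccc45)nn3)c(OC)c2)cc1`, which has the same atoms as compound 1, joined differently: 4-methoxyphenyl in place of 3-methoxyphenyl on a double-bonded chain carbon bound to a double-bonded chain carbon. The 4-methoxyphenyl group takes the place of the 3-methoxyphenyl group on a double-bonded chain carbon bound to a double-bonded chain carbon, and the rest of the structure is unchanged. Going by the values given here, with no measured precedent for this exchange, the reading of compound 1 at 70% is the only anchor, and no shift beyond the scatter is expected in this assay. The expected step of a number 4 percentage points lower from compound 1 to compound 4 (within the scatter) is accordingly small. For compound 4 the estimated value is 66%, within an expected range from 52% to 80%.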

Compound 4, percent growth inhibition at one concentration: 71%
The estimate for compound 4 lay 5 percentage points below the measured number; the measured number falls inside the stated range.
By their numbers in this assay, from the lowest: compounds 2 and 3 (each within the scatter of the next); then compounds 1 and 4 (each within the scatter of the next).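

In this assay, the exchange of 3-methoxyphenyl for 4-methoxyphenyl on a double-bonded chain carbon bound to a double-bonded chain carbon gives a step of a number 1 percentage points higher from compound 1 to compound 4 (within the scatter). For the compounds shown here, this is the first single-place comparison in the set, and it shows that, with the rest of the structure unchanged, this assay does not distinguish these two placements of the methoxy group on the phenyl ring at the one concentration tested. The measured compounds offer no explanation for this result, and no independent measurement bears on why the two readings agree.

The compounds shown leave open whether this tolerance extends to groups of a different kind at this place, such as a phenyl ring carrying an amine or a carboxylic acid in place of the methoxy group, and whether it would hold with a longer chain in the linker of compound 1. Compound 2 and compound 3 differ from compound 1 and compound 4 in more than one place, so they cannot separate the contribution of the linker from that of the aromatic group.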